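This account rests on a few compounds, and the source may have more. Where it says the series, first, only, none or still open, it means among the compounds named here.

Compound 1 `CNc1ncnc2c1c(-c1ccsc1)cn2[C@@H]1O[C@H](CO)[C@@H](O)[C@H]1O` carries a thiophen-3-yl group and a methylamino group on the shared core. In an ADME assay on BJ cells (Homo sapiens), read by MTT assay, with a stated time of 72 h (a higher number here means a weaker inhibitor, a lower number a stronger inhibitor), compound 1 gives > 100000 nM, which is a limit of the assay rather than a measured number. Compound 2 `CNc1ncnc2c1c(-c1cccs1)cn2[C@@H]1O[C@H](CO)[C@@H](O)[C@H]1O` carries thiophen-2-yl in place of thiophen-3-yl on an aromatic carbon; in this assay compound 2 gives > 100000 nM, again a limit. Compound 3 `CNc1ncnc2c1c(-c1ccoc1)cn2[C@@H]1O[C@H](CO)[C@@H](O)[C@H]1O` carries furan-3-yl in place of thiophen-3-yl on an aromatic carbon, and in this assay compound 3 gives 96300 nM. The step that the two limits leave unreadable from compound 1 to compound 2 cannot be read, and the step of an at least 1.0-fold lower number from compound 1 to compound 3 (0.01 log units; that floor lies within the scatter) stays within the scatter, so all three measured compounds sit at or close to the limit of > 100000 nM in this assay, at which 2 of the 3 values shown sit.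

Compound 4 `CN(C)c1ncnc2c1c(-c1ccsc1)cn2[C@@H]1O[C@H](CO)[C@@H](O)[C@H]1O` differs from compound 1 by methyl in place of hydrogen on a nitrogen on an aromatic ring. Among the measured compounds shown here, none of the measured steps touches the methylamino group, so no measured step bears directly on this change; what the measured compounds do show is that swapping the ring on the aromatic carbon left the read-out at or near the limit every time. Compound 4 is therefore expected to behave alike, with a step of a number no higher from compound 1 to compound 4 (the limit leaves the size open) expected, nothing beyond the scatter. Compound 4 is estimated at 100000 nM, within a range of 50000 nM to 300000 nM, and most likely reported once more as a limit.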

Compound 4, half-maximal inhibitory concentration: > 100000 nM
Compound 4 was reported as a limit; the forecaster's own chance of this, stated with the estimate: 80%; the middle value sits exactly at the limit.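

Compound 1 and compound 4 are both reported only as limits, so the change from methylamino to dimethylamino gives no step that can be read: the limit of > 100000 nM in this assay, at which 3 of the 4 values shown sit.

The compounds shown leave open how far compound 1 and compound 4 lie past that limit, and so whether the added methyl changes anything in this assay.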